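The compounds below may be only part of what the source reports. "The series", "measured", "known", "first", "only" and "open" are said of these compounds alone.

Working notes on the triazole amide series.

Of the compounds shown here, three have numbers so far. Compound 1 `C[C@H](NC(=O)c1c(C(F)(F)F)nnn1Cc1ccc(C(F)(F)F)cc1)c1ccc(C(=O)O)cc1` gives 225 nM in a functional assay on CHO cells for antagonist activity at prostaglandin E2 receptor EP4 subtype (Homo sapiens), read by calcium flux, with a stated time of 15 min; a lower number here means a stronger inhibitor, a higher number a weaker inhibitor. Compound 2 `CCCc1nnn(Cc2ccc(C(F)(F)F)cc2)c1C(=O)N[C@@H](C)c1ccc(C(=O)O)cc1` gives 68.8 nM in this assay. The step of a 3.3-fold lower number from compound 1 to compound 2 (0.51 log units; beyond the scatter) lies beyond the scatter. For the measured compounds named here, compound 3 `C[C@H](NC(=O)c1c(-c2ccccc2)nnn1Cc1cccc(C(F)(F)F)c1)c1ccc(C(=O)O)cc1` differs from compound 2 in two places, so no single step connects them; in this assay compound 3 gives 23 nM, and the two values show compound 3 with the lower number. Compound 2 therefore stands second highest of the three numbers, separated beyond the scatter from compound 3 on one side and compound 1 on the other.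

Compound 4 `C[C@H](NC(=O)c1c(C2CCCCC2)nnn1Cc1ccc(C(F)(F)F)cc1)c1ccc(C(=O)O)cc1` is not yet measured. It differs from compound 2 in one place: cyclohexyl in place of propyl on an aromatic carbon. Going by the values given here, the only measured step at this position is a 3.3-fold lower number from compound 1 to compound 2 (0.51 log units; beyond the scatter), a modest drop. Among the compounds with values here, no measured step covers the exchange of propyl for cyclohexyl, so the expectation rests on that single comparison. Since the group at this carbon was changed with a drop in a 3.3-fold lower number from compound 1 to compound 2 (0.51 log units; beyond the scatter), a further change to cyclohexyl is expected to leave the number near that of compound 2 or somewhat lower. For compound 4 in this assay the estimate is 40 nM, with a range from 12 nM to 130 nM. This estimate corresponds to an expected step of a 1.7-fold lower number from compound 2 to compound 4 (0.24 log units; within the scatter).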

Compound 4, half-maximal inhibitory concentration: 161 nM
The estimate for compound 4 lay 4.0-fold (0.60 log units) below the measured number; measured number above the stated range.
By their numbers in this assay, from the lowest: compound 3; then compound 2; then compounds 4 and 1 (each within the scatter of the next).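

In this assay, the larger cyclohexyl group does not extend the lower number seen with propyl at this aromatic carbon: a 2.3-fold higher number from compound 2 to compound 4 (0.37 log units; beyond the scatter) is a modest rise that lies beyond the scatter. Cyclohexyl and trifluoromethyl, by contrast, are not separated at this carbon, since a 1.4-fold lower number from compound 1 to compound 4 (0.15 log units; within the scatter) lies within the scatter; among these three groups, each carried with the 4-(trifluoromethyl)benzyl group, propyl alone stands apart, and the number does not simply fall as the group gets larger. No measurement available here bears on why the number rises with cyclohexyl.

Still open, going by these compounds, is whether the number at this carbon tracks chain length, which a butyl or pentyl chain would test, or depends on the ring itself, which a cyclopropyl ring would test against propyl. Also open, on these data alone, is how a propyl chain ending in an amine or a hydroxyl group would read in this assay with the rest of compound 2 held constant.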